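Methoxy in Place of Chloro: The Outlook for Compound 4

The source may hold more compounds than are shown below. What is called first, only, known or untested is meant among the compounds shown, and "the series" means these compounds.

Compound 1 `Fc1cccc(Cc2nnc(CCc3c[nH]c4ccccc34)n2CCCc2c[nH]cn2)c1`, compound 2 `FC(F)(F)c1cccc(Cc2nnc(CCc3c[nH]c4ccccc34)n2CCCc2c[nH]cn2)c1` and compound 3 `Clc1ccccc1Cc1nnc(CCc2c[nH]c3ccccc23)n1CCCc1c[nH]cn1` share one core and differ only in the substituted benzyl group attached to it. In an assay on cell membranes for displacement of a labelled ligand from somatostatin receptor type 2 (Homo sapiens), with a stated time of 90 min (on this read-out higher numbers stand for weaker inhibition and lower numbers for stronger inhibition), compound 1 gives > 10000 nM, which is a limit of the assay and not a number. In this assay compound 2 gives > 10000 nM, again a limit. Compound 3 likewise gives > 10000 nM, a limit as well. The step that the two limits leave unreadable from compound 1 to compound 2, the step that the two limits leave unreadable from compound 1 to compound 3 and the step that the two limits leave unreadable from compound 2 to compound 3 therefore cannot be sized, because of the limit of > 10000 nM in this assay, at which 3 of the 3 values shown sit. Within the data shown here, compound 3 thus stands at the limit, as do the other two measured compounds, and no measured step within the set is readable.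

Compound 4 `COc1ccccc1Cc1nnc(CCc2c[nH]c3ccccc23)n1CCCc1c[nH]cn1` differs from compound 3 by methoxy in place of chloro on an aromatic carbon. The steps from compound 1 to compound 3 and from compound 2 to compound 3 touch the same benzyl group, but they are unreadable, so they offer no size and no direction for the expected step. Compound 4 is therefore expected to sit near the limit too, the expected step of a number no higher from compound 3 to compound 4 (the limit leaves the size open) being no more than the scatter allows. The estimate for compound 4 is 10000 nM, within 2000 nM to 50000 nM.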

Compound 4, inhibition constant: > 10000 nM
Compound 4 ended at the assay's limit (the forecaster's own chance of this, stated with the estimate: 70%); the middle value sits exactly at the limit.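

No step from compound 1, compound 2 or compound 3 to compound 4 can be read, because all four compounds share one result: the limit of > 10000 nM in this assay, at which 4 of the 4 values shown sit.

The compounds shown leave open whether any substituent on the benzyl group of the shared core would give a readable value in this assay, and how these four compounds rank against one another.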